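The source may report more compounds than this note shows. Statements on the series, on what has been measured and on what is new or still open speak of the compounds shown alone.

Measured so far:
compound 1, `NC(=O)CC[C@H](NC(=O)CN(c1ncnc2c1ncn2C1CCCCO1)C1CC1)C(=O)OCc1ccccc1` — 22.3%
compound 2, `CC(C)[C@H](NC(=O)CN(c1nc(Cl)nc2[nH]cnc12)C1CC1)C(=O)OCc1ccccc1` — 27.3%

Both compounds have been run in a functional assay on the whole organism (Tail, strain ICR) with Mus musculus as the target, in the tail flick test, with a stated time of 120 min, at a dose of 25 umol/kg by the oral route; a lower number here means a weaker effect, a higher number a stronger effect of the compound at the dose given. Compound 1 gives 22.3%. Compound 2 gives 27.3%, the higher of the two numbers, yet its gap to compound 1 is within the usual scatter, so the two cannot be ranked against each other on these figures. For the measured compounds named here, no pair of measured compounds differs in a single place, so no step has yet been measured, and there is nothing to calibrate the weight of a small change on the amino-acid side chain.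

Compound 3, `CC[C@H](C)[C@H](NC(=O)CN(c1nc(Cl)nc2[nH]cnc12)C1CC1)C(=O)OCc1ccccc1`, is the next compound for this assay. It differs from compound 2 as follows:
methyl in place of hydrogen on a saturated chain carbon, three bonds along the chain from an amide-type nitrogen and a carbonyl carbon

With nothing measured on this side chain, the expectation rests on the size of the change alone. A single added carbon on a saturated chain is expected to leave the read-out where compound 2 sits; the step expected is a number 0.7 percentage points higher from compound 2 to compound 3 (within the scatter), that is, none beyond the scatter, in no particular direction. For compound 3 the estimate is 28%, with a range from 12% to 45%.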

Compound 3, a percentage reported as activity, at one dose (the size of the read-out at that dose, not a potency): 22%
Compound 3: middle estimate off by 6 percentage points, on the high side, within the range that was stated.
By their numbers in this assay, from the lowest: compounds 3, 1 and 2 (each within the scatter of the next).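

In this assay, for the compounds shown here, the isopropyl to sec-butyl change provides the first measured single-place step: a number 5.3 percentage points lower from compound 2 to compound 3 (within the scatter). Going by these compounds alone, on this read-out, methyl in place of hydrogen on this saturated chain carbon therefore gives no separation between the two compounds, and this one step gives the series a first calibration for a change of this size on the amino-acid side chain. The comparison rests on one dose and one stated time, and no measurement available here bears on the reason for the result.

On these data alone, it remains open whether a more different group at this position, such as an amine, a carboxylic acid or a longer chain in place of sec-butyl, would give a step beyond the scatter. It is also unknown whether the isopropyl to sec-butyl change would read the same at another dose or time, or on the core of compound 1, which differs from compound 2 and compound 3 in more than one place and so offers no direct comparison.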